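Removing a four-heavy-atom group on two cores

The compounds below may be only part of what the source reports. "The series", "measured", "known", "first", "only" and "open" are said of these compounds alone.

Four compounds are compared in an in vitro functional assay on 1321-N1 cells for agonist activity at P2Y purinoceptor 4 (Homo sapiens); a lower number here means that less compound is needed, a higher number that more compound is needed for the effect. Compound 1 `Cc1cc(=O)n([C@@H]2O[C@H](COP(=O)(O)OP(=O)(O)OP(=O)(O)O)[C@@H](O)[C@H]2O)c(=O)[nH]1` and compound 3 `Cc1cc(=O)n([C@@H]2O[C@H](COP(=O)(O)OP(=O)(O)O)[C@@H](O)[C@H]2O)c(=O)[nH]1` share one core; compound 2 `O=c1ccn([C@@H]2O[C@H](COP(=O)(O)OP(=O)(O)O)[C@@H](O)[C@H]2O)c(=S)[nH]1` and compound 4 `O=c1ccn([C@@H]2O[C@H](COP(=O)(O)O)[C@@H](O)[C@H]2O)c(=S)[nH]1` share another. The difference between the two cores is not broken down here.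

In this assay compound 1 gives > 100000 nM, which is a limit of the assay and not a number. Compound 3 gives > 100000 nM, again a limit. The change between them is a hydrogen atom in place of a group of 4 heavy atoms (3 oxygen, 1 phosphorus; no ring), on an oxygen, and the step it made is a step that the two limits leave unreadable from compound 1 to compound 3, since both values rest on (the limit of > 100000 nM in this assay, at which 2 of the 3 values shown sit).

Compound 2 gives > 1000 nM in this assay, which is also a limit and not a number; it sits at the limit of > 1000 nM in this assay, at which 1 of the 3 values shown sits. Compound 4 differs from compound 2 by a hydrogen atom in place of a group of 4 heavy atoms (3 oxygen, 1 phosphorus; no ring), on an oxygen, the same change as from compound 1 to compound 3, at a place described in the same words.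

What can be expected for compound 4 rests only on these limits. The step from compound 1 to compound 3 is unreadable, so the size of the expected step that the limit leaves unreadable from compound 2 to compound 4 is not anchored by a measured number; it is estimated from compound 2 already sitting at a limit and from compound 3 sitting at a limit after the same change. Compound 4 is therefore expected to give about 100000 nM, with a range from 10000 nM to 1000000 nM, and most likely the assay will again report only a limit.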

Compound 4, half-maximal effective concentration: > 100000 nM
Compound 4: a limit, no number; the forecaster's own chance of this, stated with the estimate: 85%; the middle value sits exactly at the limit.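

In this assay compound 4 gives > 100000 nM, a limit of the assay and not a number. Compound 2 gives > 1000 nM, also a limit. Going by these compounds alone, no size can be read for the step between compound 2 and compound 4, so these results yield no new step. The compounds shown leave open whether a hydrogen atom in place of this group changes the half-maximal effective concentration on either core.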